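Trimming a Methyl Group from Compound 2

A few compounds are considered here, and "the series" means these few. Any claim that something is new, unique, unknown or untested is made for them only; others in the source may bear on it.

Compound 1 `Cc1noc2c1N=C(c1cccs1)CC(c1ccccc1)C2C(c1ccccc1)C1c2onc(C)c2N=C(c2cccs2)CC1c1ccccc1` and compound 2 `Cc1ccc(C(C2c3onc(C)c3N=C(c3ccccc3)CC2c2ccccc2)C2c3onc(C)c3N=C(c3ccccc3)CC2c2ccccc2)cc1` share the same core and were both tested in a functional assay on HeLa cells (Homo sapiens) for cytotoxicity, read by MTT assay, with a stated time of 48 h; a lower number here means a stronger inhibitor, a higher number a weaker inhibitor. In this assay compound 1 gives 28.5 ug/mL, and compound 2 gives 38.4 ug/mL. Compound 2 carries the highest of the two numbers, with compound 1 nearest at a gap that falls within the usual scatter, so the two cannot be ranked against each other. Compound 3 `Cc1noc2c1N=C(c1ccccc1)CC(c1ccccc1)C2C(c1ccccc1)C1c2onc(C)c2N=C(c2ccccc2)CC1c1ccccc1` has not yet been measured in this assay. It differs from compound 2 in one place: hydrogen in place of methyl on an aromatic carbon, so that a 4-methylphenyl becomes a phenyl. Going by the values given here, with no measured pair showing what this change does on this core, there is no ground for predicting a step beyond the scatter in either direction. The step of a 1.1-fold lower number from compound 2 to compound 3 (0.04 log units; within the scatter) that the estimate implies is expected to stay within the scatter. Compound 3 is estimated at 35 ug/mL, within a range from 18 ug/mL to 70 ug/mL.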

Compound 3, half-maximal inhibitory concentration: 68.7 ug/mL
The estimate for compound 3 lay 2.0-fold (0.29 log units) below the measured number; the range from low to high includes it.
By their numbers in this assay, from the lowest: compounds 1, 2 and 3 (each within the scatter of the next, the first and the last beyond it).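

The swap of 4-methylphenyl for phenyl now has a measured pair on the shared core: in this assay it gives a 1.8-fold higher number from compound 2 to compound 3 (0.25 log units; within the scatter) and so stays inside the usual scatter. On this pair, the methyl group on this aromatic carbon can be taken away without a change that the read-out can separate from repeat-to-repeat variation. No measurement given here offers an explanation for this result.

One methyl group and one hydrogen say little about what larger or differently built groups would do at this place, such as an amine, a carboxylic acid or a longer chain like butyl. On these data alone, whether 4-methylphenyl to phenyl would give a similar step on the core of compound 1 also remains open.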